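Swapping the ethoxyphenyl amide for a dimethoxyphenyl amide

The source may report more compounds than this note shows. Statements on the series, on what has been measured and on what is new or still open speak of the compounds shown alone.

Within the data shown here, compound 3 `CCOc1ccc(NC(=O)c2cccc(/C=C3\CC(=O)N(c4ccccc4)C3=O)c2)cc1` stands highest of the two numbers known in an ADME assay on HCT-116 cells (Homo sapiens) for cytotoxicity, read by MTT assay, with a stated time of 72 h (on this read-out higher numbers stand for weaker inhibition and lower numbers for stronger inhibition), where compound 3 gives 84800 nM. Among the measured compounds shown here, its nearest neighbour, compound 1 `CCOc1ccc(NC(=O)c2cccc(/C=C3\CC(=O)N(Cc4ccccc4)C3=O)c2)cc1`, gives 41700 nM; the step of a 2.0-fold higher number from compound 1 to compound 3 (0.31 log units; beyond the scatter) is the only measured change here. Compound 2 `Cc1ccc(N2C(=O)C/C(=C\c3cccc(C(=O)Nc4cccc(F)c4)c3)C2=O)cc1` gives only a limit of the assay, > 100000 nM. The new compound 4 `COc1ccc(OC)c(NC(=O)c2cccc(/C=C3\CC(=O)N(c4ccccc4)C3=O)c2)c1` differs from compound 3 by 2,5-dimethoxyphenyl in place of 4-ethoxyphenyl on an amide-type nitrogen. For the measured compounds named here, no measured step touches this part of the shared core: the one known step changes the ring nitrogen instead. With nothing to lean on, compound 4 is expected to stay near compound 3, with an estimated step of a 1.0-fold higher number from compound 3 to compound 4 (0.00 log units; within the scatter). Compound 4 is therefore expected to give about 85000 nM, somewhere between 40000 nM and 200000 nM.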

Compound 4, half-maximal inhibitory concentration: > 100000 nM
Compound 4 ended at the assay's limit (the forecaster's own chance of this, stated with the estimate: 35%); at least 1.1-fold (0.07 log units) between middle value and limit.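

The earlier compounds shown here gave no step at this amide-type nitrogen, and 2,5-dimethoxyphenyl in place of 4-ethoxyphenyl now gives an at least 1.1-fold higher number from compound 3 to compound 4 (0.07 log units; that floor lies within the scatter). This change brings no stronger inhibition, but its true size stays hidden, because compound 4 sits at a limit of the assay rather than at a number: the limit of > 100000 nM in this assay, at which 2 of the 4 values shown sit.

Still open, from the compounds shown here alone, is whether any group here can bring the number down, for instance a phenyl ring carrying an amine or a carboxylic acid. Also open, going by these compounds, is whether 2,5-dimethoxyphenyl would act the same way alongside the benzyl group of compound 1.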